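The compounds below may be only part of what the source reports. "The series", "measured", "known", "first", "only" and "open" are said of these compounds alone.

Compound 1 `Cc1ccc(S(=O)(=O)Cc2nc(Nc3ccccc3)c3ccccc3n2)cc1`: "nd(insoluble)" (no result reported)
Compound 2 `Cc1ccc(S(=O)(=O)Cc2nc(Nc3ccc(F)cc3)c3ccccc3n2)cc1`: > 15000 nM

In an ADME assay on HepG2 cells (Homo sapiens) for cytotoxicity, read by MTT assay, with a stated time of 72 h (on this read-out higher numbers stand for weaker inhibition and lower numbers for stronger inhibition), compound 2 gives > 15000 nM, which is a limit of the assay and not a number. Compound 1 provides no number, so compound 2 has no measured neighbour to be compared with. The only reference so far is the limit of > 15000 nM in this assay, at which 1 of the 2 values shown sits.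

Compound 3 `Cc1ccc(S(=O)(=O)Cc2nc(Nc3cccc(Br)c3)c3ccccc3n2)cc1` has not yet been measured. It differs from compound 2 as follows: 3-bromophenyl in place of 4-fluorophenyl on a nitrogen on an aromatic ring. In words, 3-bromophenyl stands in place of 4-fluorophenyl on a nitrogen on an aromatic ring.

Among the measured compounds shown here, no measured step is available to size this change, and no step beyond the scatter is expected in this assay. That expectation rests on compound 2 alone, with its limit of > 15000 nM. The estimate means an expected step that the limit leaves unreadable from compound 2 to compound 3. Compound 3 is expected at 20000 nM, with an estimated range of 8000 nM to 50000 nM.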

Compound 3, half-maximal inhibitory concentration: > 15000 nM
Compound 3 was reported as a limit; the forecaster's own chance of this, stated with the estimate: 60%; the middle value does not contradict the limit.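

In this assay compound 3 gives > 15000 nM, which is a limit of the assay. Compound 2 gives > 15000 nM, also a limit, so no step can be read between compound 2 and compound 3. The compounds shown leave open whether exchanging 4-fluorophenyl for 3-bromophenyl changes this read-out at all.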